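Swapping the aryl group on the shared core of compound 1

The compounds below may be only part of what the source reports. "The series", "measured", "known", "first", "only" and "open" are said of these compounds alone.

The study follows a small set of compounds sharing one core, differing in the aryl group on a saturated ring carbon and in the ester. Compound 1 `COc1ccc(C2C(C(=O)OCc3ccccn3)=C(C)NC3=C2C(=O)CCC3)cc1` gives 1.9 in a physicochemical assay for lipophilicity, measured as octanol-water partition (a higher number here means a more lipophilic compound, a lower number a more polar compound), the highest of the three numbers recorded. Compound 2 `CC1=C(C(=O)OCc2cccnc2)C(c2ccc(C#N)cc2)C2=C(CCCC2=O)N1` gives 1.36 in this assay, and compound 3 `CC1=C(C(=O)OCc2cccnc2)C(c2cccc(O)c2)C2=C(CCCC2=O)N1` gives 1.21, both beyond the scatter below compound 1. Within the data shown here, the only single-point step recorded is the aryl swap a number 0.15 log units lower from compound 2 to compound 3 (within the scatter), a change within the scatter.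

Compound 4 `CC1=C(C(=O)OCc2ccccn2)C(c2cccc([N+](=O)[O-])c2)C2=C(CCCC2=O)N1` is yet to be measured. It differs from compound 1 in one place: 3-nitrophenyl in place of 4-methoxyphenyl on a saturated ring carbon. Among the measured compounds shown here, the step from compound 2 to compound 3 is the only measured change that bears on this, and it is small, so the aryl swap from compound 1 to compound 4 is expected to move this assay by little more than the scatter, downward if anything, a number 0.25 log units lower from compound 1 to compound 4 (within the scatter). Compound 4 is therefore estimated at 1.65, within 1.35 to 1.95.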

Compound 4, partition coefficient: 1.88
Estimate against measurement, compound 4: 0.23 log units below; measured number inside the range.
By their numbers in this assay, from the lowest: compounds 3 and 2 (each within the scatter of the next); then compounds 4 and 1 (each within the scatter of the next).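

In this assay, 3-nitrophenyl in place of 4-methoxyphenyl on the saturated ring carbon gives a number 0.02 log units lower from compound 1 to compound 4 (within the scatter), so this exchange does not separate the two compounds while the ((pyridin-2-yl)methoxy)carbonyl group stays in place. This is the first step shown at this position with that ester, and it joins a number 0.15 log units lower from compound 2 to compound 3 (within the scatter), so both aryl swaps shown here lie within the scatter, with different aryl groups and a different ester. Nothing measured here explains why the number holds across this change.

The compounds shown leave open whether an aryl group carrying an amine or a carboxylic acid on this carbon would also stay within the scatter. No pair shown differs in the ester alone, so the gap between the two pairs of compounds cannot be assigned to the ester or to the aryl group.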